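This account rests on a few compounds, and the source may have more. Where it says the series, first, only, none or still open, it means among the compounds named here.

Working notes on the series. Compound 1 `COc1ccccc1-n1nncc1CN1C(=O)C2(C(C#N)=C(N)Oc3c2c2nc4ccccc4nc2c2ccccc32)c2ccccc21` and compound 2 `COc1ccc(-n2nncc2CN2C(=O)C3(C(C#N)=C(N)Oc4c(N)cc5nc6ccccc6nc5c43)c3ccccc32)cc1` share one core and have both been tested in a functional assay on HCT-116 cells (Homo sapiens) for antiproliferative activity, read by MTT assay, with a stated time of 48 h; on this read-out higher numbers stand for weaker inhibition and lower numbers for stronger inhibition. Compound 1 gives > 50000 nM, which is a limit of the assay and not a number. Compound 2 likewise gives > 50000 nM, again a limit of the assay rather than a measured value. Where compound 2 stands is therefore only bounded: everything shown so far sits at one point, (the limit of > 50000 nM in this assay, at which 2 of the 2 values shown sit), and no step between measured compounds can be drawn from it.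

Compound 3 `Cc1ccc(Cl)cc1-n1nncc1CN1C(=O)C2(C(C#N)=C(N)Oc3c(N)cc4nc5ccccc5nc4c32)c2ccccc21` is the next member, still to be measured in this assay. It differs from compound 2 by 5-chloro-2-methylphenyl in place of 4-methoxyphenyl on an aromatic nitrogen. Going by the values given here, with both known values at the limit, there is no measured step to lean on for direction or size. The expectation is that this change will not move the read-out beyond the scatter, so compound 3 is expected to remain at or near the limit, with a step that the limit leaves unreadable from compound 2 to compound 3 expected to be no more than the usual scatter. Compound 3 is estimated at 60000 nM, in the range 20000 nM to 200000 nM, and will most probably be reported once more as a limit.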

Compound 3, half-maximal inhibitory concentration: 37200 nM
Beside the measured number, compound 3's estimate is 1.6-fold (0.21 log units) above it, and the stated range covers the measured number.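

In this assay, 5-chloro-2-methylphenyl in place of 4-methoxyphenyl on the aromatic nitrogen gives an at least 1.3-fold lower number from compound 2 to compound 3 (0.12 log units; that floor lies within the scatter). Going by these compounds alone, compound 3 thus carries the only value in the set that is a number and not a limit, which shows that a substituted phenyl at this position can give a read-out inside the range of the assay. The step remains only a floor, so it establishes neither a true size for this change nor a shift beyond the scatter, and the rest of the set still offers no second number to read it against: the limit of > 50000 nM in this assay, at which 2 of the 3 values shown sit.

On these data alone, it remains open which part of the exchange matters, whether the chlorine, the methyl or the departure of the methoxy, since the entering and leaving groups differ in all of these at once. As far as these compounds go, it is equally open whether an unsubstituted phenyl, a phenyl bearing an amine or a carboxylic acid, or a longer alkyl chain on this nitrogen would bring the read-out clearly beyond the scatter, in either direction.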